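Ester in Place of Amide on a Cinnamoyl Pyridine

The source may hold more compounds than are shown below. What is called first, only, known or untested is meant among the compounds shown, and "the series" means these compounds.

Measured compounds:
compound 1 `COC1CN(C(=O)/C=C/c2ccncc2-c2ccc3ccccc3c2)C1` — 100%
compound 2 `COc1ccc(-c2cnccc2/C=C/C(=O)N2CC(OC)C2)cc1OC` — 87%
compound 3 `Cn1ccc2cc(-c3cnccc3/C=C/C(=O)N3CCOCC3)ccc21` — 97%

Of the compounds shown here, three have been measured in an assay on a protein complex for inhibition of CDK8/Cyclin C (Homo sapiens), with a stated time of 1 h, tested at 10 uM; a lower number here means less inhibition, a higher number more inhibition at the concentration tested (going by the name of the read-out). Compound 1 gives 100%, the highest of the three numbers. Compound 3 gives 97%, a number within the usual scatter of compound 1, so the two cannot be told apart. Compound 2 gives 87%, which lies beyond the scatter below compound 1, and on this pair alone compound 1 shows the stronger inhibition.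

The unmeasured compound 4 `CCOC(=O)/C=C/c1ccncc1-c1ccc2ccccc2c1` is derived from compound 1 by a single change: ethoxy in place of 3-methoxyazetidin-1-yl on a carbonyl carbon. The carbonyl itself stays, so the amide of compound 1 becomes an ester in compound 4. Within the data shown here, no measured pair shows this change, so its effect rests on expectation alone. A modest downward step is expected, since the starting number of compound 1 is already at the top of the read-out and can only hold or fall; the step from compound 1 to compound 4 is estimated at a number 25 percentage points lower from compound 1 to compound 4 (beyond the scatter). Compound 4 is therefore expected to give about 75%, within a range from 40% to 98%.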

Compound 4, a percentage reported as inhibition, at one concentration (the size of the read-out at that concentration, not a potency): 102%
Estimate against measurement, compound 4: 27 percentage points below, outside the stated range (above it).
By their numbers in this assay, from the lowest: compounds 2, 3, 1 and 4 (each within the scatter of the next, the first and the last beyond it).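

In this assay, ethoxy in place of 3-methoxyazetidin-1-yl on a carbonyl carbon gives a number 2 percentage points higher from compound 1 to compound 4 (within the scatter), so the amide and the ester cannot be told apart here. Among these compounds, no earlier pair differed in one place alone, and this step shows that the ring of the amide can give way to an open ethoxy group with no readable change in inhibition, though with both numbers at the top of the read-out, this single concentration cannot show any difference in potency. No measurement shown here explains this result.

The compounds shown leave open how a carboxylic acid or a longer chain such as butoxy would read on the same carbonyl carbon. They also leave open whether a simple dimethylamine amide would match the ester, and how either compound would compare at lower concentrations.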